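A few compounds are considered here, and "the series" means these few. Any claim that something is new, unique, unknown or untested is made for them only; others in the source may bear on it.

Compounds measured in a functional assay on MCF7 cells (Homo sapiens) for inhibition (a lower number here means a stronger inhibitor, a higher number a weaker inhibitor), so far:

- compound 1, `CCn1c(=O)/c(=C2\Sc3ccc(OC)cc3N2C)s/c1=C\c1ccncc1Nc1ccccc1C`: 420 nM
- compound 2, `CCn1c(=O)/c(=C2\Sc3ccc(OC)cc3N2C)s/c1=C\c1ccncc1Nc1ccccc1Cl`: 710 nM
- compound 3, `CCn1c(=O)/c(=C2\Sc3ccc(C)cc3N2C)s/c1=C\c1ccncc1Nc1ccccc1F`: 100 nM

Compound 3 stands lowest of the three numbers. Against compound 1 it is lower by a margin beyond the scatter, and against compound 2 by a larger margin still. Among the compounds with values here, the only single-point step recorded within the set is a 1.7-fold higher number from compound 1 to compound 2 (0.23 log units; within the scatter), which concerns a different position of the shared core and stays within the scatter; it says nothing about the change examined here.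

Compound 4, `CCn1c(=O)/c(=C2\Sc3ccc(OC)cc3N2C)s/c1=C\c1ccncc1Nc1ccccc1F`, is not yet measured. Relative to compound 3 the change is methoxy in place of methyl on an aromatic carbon. Within the data shown here, no measured pair isolates this exchange: compound 3 differs from compound 1 in two places at once, so the gap between them cannot be assigned to either change. Among the measured compounds shown here, the only pointer is that compounds 1 and 2, which both carry the methoxy at this position, give higher numbers than compound 3. The step of a 2.2-fold higher number from compound 3 to compound 4 (0.34 log units; beyond the scatter) is therefore expected as a moderately higher number, carrying wide uncertainty. Compound 4 is expected to give 220 nM in this assay, estimated between 80 nM and 600 nM.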

Compound 4, half-maximal inhibitory concentration: 130 nM
Beside the measured number, compound 4's estimate is 1.7-fold (0.23 log units) above it; the range from low to high includes it.
By their numbers in this assay, from the lowest: compounds 3 and 4 (each within the scatter of the next); then compounds 1 and 2 (each within the scatter of the next).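

In this assay, the exchange of methoxy in place of methyl, on an aromatic carbon meta to a fused ring and para to a fused ring, is now isolated in one pair: a 1.3-fold higher number from compound 3 to compound 4 (0.11 log units; within the scatter), so the two groups cannot be told apart at this position in this setting. With methoxy held constant, fluoro in place of chloro gives a 5.5-fold lower number from compound 2 to compound 4 (0.74 log units; beyond the scatter), and fluoro in place of methyl gives a 3.2-fold lower number from compound 1 to compound 4 (0.51 log units; beyond the scatter), which places the differences seen among these compounds at the aromatic carbon carrying fluoro, chloro or methyl and not at the methoxy position. Nothing available beyond these numbers accounts for either finding.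

Methyl and methoxy are the only groups shown at this position, so it remains open whether an amine, a carboxylic acid or a longer chain such as ethoxy would keep the number in the same range. Going by these compounds, it is also open whether the methoxy and methyl exchange stays this small with chloro or methyl in place of fluoro, and how a nitrile or hydroxy group at that carbon would compare with fluoro.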